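The compounds below may be only part of what the source reports. "The series", "measured", "known", "first", "only" and "open" are said of these compounds alone.

Measured so far in a physicochemical assay for lipophilicity; on this read-out higher numbers stand for higher lipophilicity and lower numbers for lower lipophilicity:
- compound 1 `CC#CCn1c(N2CCC[C@@H](N)C2)cc(=O)n(Cc2cc(C)cc(C)c2)c1=O` gives 2.78
- compound 2 `Cc1cc(C)cc(Cn2c(=O)cc(N3CCC[C@@H](N)C3)n(Cc3cc(F)ccc3C#N)c2=O)c1` gives 3.89

Compound 1 holds the lower of these two numbers. Compound 3 `CC#CCn1c(N2CCC[C@@H](N)C2)cc(=O)n(CCC)c1=O` has ethyl in place of 3,5-dimethylphenyl on a saturated chain carbon bound to an aromatic nitrogen when set against compound 1. Among the measured compounds shown here, only one measured step bears on this, and there a ring came in: a number 1.11 log units higher from compound 1 to compound 2 (beyond the scatter) with 2-cyano-5-fluorophenyl in place of prop-1-yn-1-yl. Here a ring leaves, so a large downward step of similar size is expected in this assay on that single precedent. The estimated change is a number 1.18 log units lower from compound 1 to compound 3 (beyond the scatter) for this replacement. For compound 3 the expected value is 1.6 with an estimated range from 1 to 2.2 at this stage.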

Compound 3, partition coefficient: 0.9
The estimate for compound 3 lay 0.70 log units above the measured number; the whole stated range lies above it.
By their numbers in this assay, from the lowest: compound 3; then compound 1; then compound 2.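

In this assay, the change from 3,5-dimethylbenzyl to propyl gives a number 1.88 log units lower from compound 1 to compound 3 (beyond the scatter), a large step. With the rest of compound 1 unchanged, this single replacement is enough to carry the number beyond the scatter, so the read-out responds strongly to the group at this place. On these data alone, whether a plain benzyl, a longer chain such as butyl, or a chain ending in an amine would fall between compound 3 and compound 1 remains open. No measurement shown here accounts for the size of this step.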